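This account rests on a few compounds, and the source may have more. Where it says the series, first, only, none or still open, it means among the compounds named here.

Working notes on the N-alkyl series.

Compound 1 `CCCCCCCCN[C@@H]1C=C[C@H](O)[C@H](O)[C@H]1O` gives 120000 nM in an assay for inhibition of beta-galactosidase (Homo sapiens), read by fluorescence, with a stated time of 30 min, at pH 4.5; on this read-out lower numbers stand for stronger inhibition and higher numbers for weaker inhibition. Compound 2 `CCCCN[C@@H]1C=C[C@H](O)[C@H](O)[C@H]1O` gives 50000 nM, and compound 3 `CCCCCN[C@@H]1C=C[C@H](O)[C@H](O)[C@H]1O` gives 19000 nM, the lowest of the three numbers: a 2.6-fold lower number from compound 2 to compound 3 (0.42 log units; beyond the scatter), a 6.3-fold lower number from compound 1 to compound 3 (0.80 log units; beyond the scatter). Compound 4 `CCCCCCN[C@@H]1C=C[C@H](O)[C@H](O)[C@H]1O` is not yet measured; it differs from compound 3 by methyl in place of hydrogen on a saturated chain carbon, five bonds along the chain from an amine nitrogen.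

The nearest comparison is the chain extension a 2.6-fold lower number from compound 2 to compound 3 (0.42 log units; beyond the scatter), which lowered the number, but the further extension recorded as a 2.4-fold lower number from compound 1 to compound 2 (0.38 log units; beyond the scatter) runs the other way, so the chain of compound 1 ends up with the highest number. Compound 4 sits between these two in chain length, so no step beyond the scatter is expected: the estimated step from compound 3 to compound 4 is a 1.3-fold higher number from compound 3 to compound 4 (0.12 log units; within the scatter). For compound 4 the expected value is 25000 nM, with a range from 8000 nM to 80000 nM.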

Compound 4, half-maximal inhibitory concentration: 56000 nM
For compound 4 the middle estimate is 2.2-fold (0.35 log units) below the measured one; low and high end bracket the measured number.
By their numbers in this assay, from the lowest: compound 3; then compounds 2 and 4 (each within the scatter of the next); then compound 1.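

In this assay, methyl in place of hydrogen five bonds along the chain from an amine nitrogen reverses the earlier gain from chain extension (a 2.9-fold higher number from compound 3 to compound 4 (0.47 log units; beyond the scatter)). Ethyl in place of hydrogen four bonds along the chain therefore leaves no separation beyond the scatter (a 1.1-fold higher number from compound 2 to compound 4 (0.05 log units; within the scatter)), while hydrogen in place of ethyl six bonds along the chain still lowers the number (a 2.1-fold lower number from compound 1 to compound 4 (0.33 log units; beyond the scatter)). No evidence on the origin of this reversal is at hand.

Going by these compounds, whether a heptyl chain would fit this trend remains open. So does the effect of a branched chain or a terminal hydroxyl group at this position.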